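Swapping chloro for bromo on compound 2

This account rests on a few compounds, and the source may have more. Where it says the series, first, only, none or still open, it means among the compounds named here.

In a functional assay on T29Kt1 cells (Homo sapiens) for cytotoxicity, read by sulforhodamine B assay, with a stated time of 3 days (a higher number here means a weaker inhibitor, a lower number a stronger inhibitor), compound 2 `OCc1cn(Cc2cccc(Cl)c2)c2ccccc12` gives 160 nM, the lower of the two numbers available. Compound 1 `O=Cc1cn(Cc2cccc(Br)c2)c2ccccc12` gives 1580 nM, a gap beyond the scatter. Compound 3 `OCc1cn(Cc2cccc(Br)c2)c2ccccc12` has bromo in place of chloro on an aromatic carbon, meta to a large group (bromo in place of chloro on an aromatic carbon). Going by the values given here, no measured pair isolates this change, as compound 1 also differs from compound 2 elsewhere. No step beyond the scatter is therefore expected in this assay. The expected step is a 1.1-fold higher number from compound 2 to compound 3 (0.03 log units; within the scatter). For compound 3 the estimated value is 170 nM, with a range of 65 nM to 450 nM.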

Compound 3, half-maximal inhibitory concentration: 32 nM
Beside the measured number, compound 3's estimate is 5.3-fold (0.73 log units) above it; the whole stated range lies above it.
By their numbers in this assay, from the lowest: compound 3; then compound 2; then compound 1.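

In this assay, going by these compounds alone, the aromatic halogen is not a silent place on the shared core: bromo in place of chloro gives a 5.0-fold lower number from compound 2 to compound 3 (0.70 log units; beyond the scatter) and is the first reading of this change on its own. With bromo held constant, hydroxymethyl in place of formyl gives a 49-fold lower number from compound 1 to compound 3 (1.69 log units; beyond the scatter) and shows that the other group also matters in this series. Nothing measured here accounts for either step.

From the compounds shown here alone, whether fluoro or iodo would extend the halogen step remains open. So does the outcome of an amine or a carboxylic acid in place of hydroxymethyl.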